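A Chloro Step Measured Against Two Limits

The source may report more compounds than this note shows. Statements on the series, on what has been measured and on what is new or still open speak of the compounds shown alone.

Compound 1 `CCN(CC)CN1C(=O)/C(=N/NC(=S)Nc2ccccc2)c2ccccc21` and compound 2 `CCN(CC)CN1C(=O)/C(=N/NC(=S)Nc2ccc(C)cc2)c2ccccc21` share one core and differ by methyl in place of hydrogen on an aromatic carbon. In an ADME assay on HeLa cells (Homo sapiens) for cytotoxicity (on this read-out lower numbers stand for higher toxicity in this test and higher numbers for lower toxicity in this test), compound 1 gives only the limit >= 20000 nM. In this assay compound 2 likewise gives only the limit >= 20000 nM. For the measured compounds named here, the step that the two limits leave unreadable from compound 1 to compound 2 therefore cannot be read, and compound 2 stands at the limit of >= 20000 nM in this assay, at which 2 of the 2 values shown sit, the single value shown for it. Compound 3 `CCN(CC)CN1C(=O)/C(=N/NC(=S)Nc2ccc(C)cc2)c2cc(Cl)ccc21` arises from compound 2 by chloro in place of hydrogen on an aromatic carbon. Going by the values given here, the only measured step bears on this change solely in that both of its ends sit at the same limit, so it offers no size to carry over. For compound 3 in this assay a step that the limit leaves unreadable from compound 2 to compound 3 is expected, none beyond the scatter. Compound 3 is estimated at 25000 nM, between 10000 nM and 60000 nM, most likely again reported as a limit.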

Compound 3, minimum cytotoxic concentration: >= 4000 nM
Compound 3: a limit, no number; the forecaster's own chance of this, stated with the estimate: 75%; the middle value lies beyond the limit too.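

Compound 2 and compound 3 are both reported only as limits, not as numbers, so the step between them cannot be read. The compounds shown leave open whether chloro in place of hydrogen on this aromatic carbon changes the result in this assay at all, and by how much.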